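The source may hold more compounds than are shown below. What is called first, only, known or untested is meant among the compounds shown, and "the series" means these compounds.

In a functional assay on Huh-7 cells (Homo sapiens) for antiproliferative activity, read by sulforhodamine B assay, with a stated time of 72 h (a higher number here means a weaker inhibitor, a lower number a stronger inhibitor), compound 1 `Nc1nc(N2CCN(C(c3ccccc3)c3ccccc3)CC2)c2ncn([C@@H]3O[C@H](CO)[C@@H](O)[C@H]3O)c2n1` stands at 10000 nM against compound 2 `CC(C)c1ccc(Nc2ncnc3c2ncn3[C@@H]2O[C@H](CO)[C@@H](O)[C@H]2O)cc1` at 60000 nM as the higher of the two numbers, a gap beyond the scatter. Compound 3 `OC[C@H]1O[C@@H](n2cnc3c(NCCNc4ccccc4)ncnc32)[C@H](O)[C@@H]1O`, not yet measured, follows from compound 2 through 2-anilinoethyl in place of 4-isopropylphenyl on a nitrogen on an aromatic ring with 2-anilinoethyl in place of 4-isopropylphenyl on a nitrogen on an aromatic ring. Going by the values given here, no measured step covers this change, so the expectation stays anchored on compound 2 at 60000 nM with no step beyond the scatter expected in this assay for this swap. The estimated 1.5-fold lower number from compound 2 to compound 3 (0.18 log units; within the scatter) is small and leans toward a lower number. Compound 3 is estimated at 40000 nM with an expected range from 15000 nM to 100000 nM in this series.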

Compound 3, half-maximal inhibitory concentration: "not active" (no number reported)
No number was reported for compound 3; the estimate stays without a comparison.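

Going by these compounds alone, compound 3 is reported as not active, with no number, in this assay, so no step from compound 2 to compound 3 can be read. Nothing available bears on this result. The compounds shown leave open how 2-anilinoethyl compares in size of effect with 4-isopropylphenyl.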